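Benzyl to propyl on the aromatic nitrogen

A few compounds are considered here, and "the series" means these few. Any claim that something is new, unique, unknown or untested is made for them only; others in the source may bear on it.

In a functional assay on HepG2 cells (Homo sapiens) for antiproliferative activity, read by CCK-8 assay, with a stated time of 72 h, tested at 2 uM (on this read-out higher numbers stand for a stronger effect at the one concentration tested and lower numbers for a weaker effect), compound 1 `COC(CCn1cnc2c(NCc3ccc(C(=O)Nc4ccccc4N)cc3)nc(Cl)nc21)OC` gives 8.52% and compound 2 `CC(C)n1cnc2c(NCc3ccc(C(=O)Nc4ccccc4N)cc3)nc(Cl)nc21` gives 63.8%. Compound 3 `Nc1ccccc1NC(=O)c1ccc(CNc2nc(Cl)nc3c2ncn3Cc2ccccc2)cc1` gives 5.01% in this assay, the lowest of the three numbers, with a number 3.5 percentage points lower from compound 1 to compound 3 (within the scatter) and a number 58.8 percentage points lower from compound 2 to compound 3 (beyond the scatter). Compound 4 `CCCn1cnc2c(NCc3ccc(C(=O)Nc4ccccc4N)cc3)nc(Cl)nc21` differs from compound 3 by ethyl in place of phenyl on a saturated chain carbon bound to an aromatic nitrogen. For the measured compounds named here, two steps bear on this: a number 58.8 percentage points lower from compound 2 to compound 3 (beyond the scatter) and a number 55.3 percentage points higher from compound 1 to compound 2 (beyond the scatter), both large, showing that the group on the aromatic nitrogen governs the read-out, whereas a number 3.5 percentage points lower from compound 1 to compound 3 (within the scatter). Propyl resembles the isopropyl of compound 2 more than the benzyl of compound 3, so a rise is expected, though its size is uncertain because only compound 2 supports a high value with 63.8%. For compound 4 the expected step is a number 27 percentage points higher from compound 3 to compound 4 (beyond the scatter), giving an estimated 32% with a range from 5% to 65%.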

Compound 4, a percentage reported as inhibition, at one concentration (the size of the read-out at that concentration, not a potency): 12.4%
Estimate against measurement, compound 4: 19.6 percentage points above, and the stated range covers the measured number.
By their numbers in this assay, from the lowest: compounds 3, 1 and 4 (each within the scatter of the next); then compound 2.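

In this assay the straight propyl does not keep the read-out of the branched isopropyl, with a number 51.4 percentage points lower from compound 2 to compound 4 (beyond the scatter) for this change on an aromatic nitrogen. Benzyl to propyl gives a number 7.4 percentage points higher from compound 3 to compound 4 (within the scatter) and the dimethoxy chain to propyl gives a number 3.9 percentage points higher from compound 1 to compound 4 (within the scatter) on the same nitrogen. Compounds 1, 3 and 4 thus sit together, and the high value rests on compound 2 alone.

No evidence shown accounts for the gap between propyl and isopropyl. Going by these compounds, whether cyclopropyl or tert-butyl on this nitrogen would hold the value of compound 2 remains open.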